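Fluoro-to-hydrogen step on the nitrophenyl ring

The source may hold more compounds than are shown below. What is called first, only, known or untested is meant among the compounds shown, and "the series" means these compounds.

Measured compounds:
- Compound 1 `Nc1nc(N)c(CCCNc2cc(F)ccc2[N+](=O)[O-])c(O)n1`: in a functional assay on CCRF-CEM cells (Homo sapiens) for cytotoxicity, in the presence of a further agent that is not named here (a higher number here means a weaker inhibitor, a lower number a stronger inhibitor), compound 1 gives > 100000 nM, which is a limit of the assay and not a number.
- Compound 2 `Nc1nc(N)c(CCCNc2cc(F)cc(F)c2[N+](=O)[O-])c(O)n1`: in this assay compound 2 gives 94000 nM.
- Compound 3 `CC(C)(C)OC(=O)CCC(Nc1ccc(CN(CCCc2c(N)nc(N)nc2O)c2cc(F)cc(F)c2[N+](=O)[O-])cc1)C(=O)OC(C)(C)C`: in this assay compound 3 gives 7700 nM.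

Compound 1 and compound 2 differ by one change, (hydrogen in place of fluoro on an aromatic carbon). The step it made in this assay is an at least 1.0-fold higher number from compound 2 to compound 1 (0.02 log units; that floor lies within the scatter); its size is open-ended because the limit of > 100000 nM in this assay, at which 1 of the 3 values shown sits, applies to compound 1, so only a floor is known, and that floor lies within the scatter.

Compound 3 carries a larger part on the same nitrophenyl ring; the difference between its core and that of compound 2 is not broken down here. In this assay compound 3 stands lowest of the two numbers, well beyond the scatter from compound 2.

Compound 4 `CC(C)(C)OC(=O)CCC(Nc1ccc(CN(CCCc2c(N)nc(N)nc2O)c2cc(F)ccc2[N+](=O)[O-])cc1)C(=O)OC(C)(C)C` is not yet measured. It relates to compound 3 by hydrogen in place of fluoro on an aromatic carbon, the same change that took compound 2 to compound 1, at the same place around the ring. The expectation for compound 4 in this assay rests on that earlier step: from compound 2 to compound 1 the number did not fall, so the estimated step is a 1.8-fold higher number from compound 3 to compound 4 (0.26 log units; within the scatter), a somewhat higher number, with wide uncertainty since the earlier step has only a floor. Compound 4 is thus expected to give about 14000 nM in this assay, between 5000 nM and 45000 nM.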

Compound 4, half-maximal inhibitory concentration: 14000 nM
For compound 4 middle estimate and measured number coincide at the digits printed; the measured number falls inside the stated range.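

Hydrogen in place of fluoro, read one bond further out as 3,5-difluoro-2-nitrophenyl to 5-fluoro-2-nitrophenyl, now has a step with a number at both ends on the larger core in this assay: a 1.8-fold higher number from compound 3 to compound 4 (0.26 log units; within the scatter). Set beside the step on the smaller core, this can be compared only in part: the same change on two cores in this assay, an at least 1.0-fold higher number (0.02 log units; that floor lies within the scatter) from compound 2 to compound 1 and a 1.8-fold higher number (0.26 log units; within the scatter) from compound 3 to compound 4; the limit leaves it open whether they differ. The larger core therefore shows a change that stays inside the scatter, and nothing printed for the two cores contradicts that, but carry-over of the step's size from one core to the other is not shown, since on the smaller core only a floor is known and the value of compound 1 is a limit of the assay and not a number: the limit of > 100000 nM in this assay, at which 1 of the 4 values shown sits.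

The compounds shown cover only hydrogen and fluoro at this place on the nitrophenyl ring, so a step to chloro or to a methoxy group there remains open. Also open, from the compounds shown here alone, is whether the same change reads alike on a core with free carboxylic acids in place of the two tert-butyl esters, or with an amine in place of the nitro group.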